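The compounds below may be only part of what the source reports. "The series", "measured", "known", "first", "only" and "open" are said of these compounds alone.

Measured so far in a functional assay on HCT-116 cells (Homo sapiens), read by MTT assay, with a stated time of 72 h; on this read-out higher numbers stand for weaker inhibition and lower numbers for stronger inhibition:

compound 1 `Nc1nc(N)c2c(-c3ccsc3)cn([C@@H]3O[C@H](CO)[C@@H](O)[C@H]3O)c2n1` gives > 20000 nM.
compound 2 `C#Cc1cn([C@@H]2O[C@H](CO)[C@@H](O)[C@H]2O)c2ncnc(C)c12` gives > 20000 nM.
compound 3 `COc1nc(N)nc2c1c(-c1ccsc1)cn2[C@@H]1O[C@H](CO)[C@@H](O)[C@H]1O` gives > 20000 nM.

Each of these three values is a limit of this assay, not a number. Compound 2 therefore stands only at a limit, with no number to set it against the other two, which likewise sit at limits. Going by the values given here, the one change measured, methoxy in place of amino on an aromatic carbon, runs from compound 1 to compound 3 and comes out as a step that the two limits leave unreadable from compound 1 to compound 3, unreadable because both ends sit at the limit of > 20000 nM in this assay, at which 3 of the 3 values shown sit. Among the compounds with values here, no measured step thus shows a size or a direction.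

Compound 4 `Cc1ncnc2c1c(-c1ccoc1)cn2[C@@H]1O[C@H](CO)[C@@H](O)[C@H]1O` differs from compound 2 in one place: furan-3-yl in place of ethynyl on an aromatic carbon. Within the data shown here, none of the measured steps bears on this change, and the sole step measured is itself unreadable, so no step of any particular size is expected in this assay for the change from compound 2 to compound 4; the most likely outcome is that compound 4 also returns only the limit. Compound 4 is accordingly expected to give about 30000 nM, with a range from 8000 nM to 100000 nM. The step this estimate means from compound 2 to compound 4 is a step that the limit leaves unreadable from compound 2 to compound 4, which is expected to stay unreadable.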

Compound 4, half-maximal inhibitory concentration: > 20000 nM
Compound 4 ended at the assay's limit; the forecaster's own chance of this, stated with the estimate: 85%; the middle value is on the limit's open side.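

In this assay compound 4 gives > 20000 nM, which is a limit and not a number. With compound 2 also at a limit, the change to furan-3-yl in place of ethynyl cannot be read as a step: the limit of > 20000 nM in this assay, at which 4 of the 4 values shown sit.

The compounds shown leave open the size and direction of both single changes; none of them returns a number.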